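The source may report more compounds than this note shows. Statements on the series, on what has been measured and on what is new or still open speak of the compounds shown alone.

Measured so far in an assay on CHO cells for displacement of a labelled ligand from Neuronal acetylcholine receptor; alpha3/alpha6/beta2/beta3 (Homo sapiens), read by scintillation counting; a lower number here means a stronger inhibitor, a higher number a weaker inhibitor:

compound 1, `CC(=O)N1CC2CC(C1)N2`: 610 nM
compound 2, `CCCC(=O)N1CC2CC(C1)N2`: 350 nM
compound 3, `O=C([C@H]1C[C@H]1F)N1CC2CC(C1)N2`: 27 nM

Compound 3 holds the lowest of the three numbers; the steps of a 23-fold lower number from compound 1 to compound 3 (1.35 log units; beyond the scatter) and a 13-fold lower number from compound 2 to compound 3 (1.11 log units; beyond the scatter) both lie beyond the scatter, so on these numbers compound 3 is the strongest inhibitor of the set. The step of a 1.7-fold lower number from compound 1 to compound 2 (0.24 log units; within the scatter) lies within the scatter, so the numbers of compound 1 and compound 2 are not separated.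

Compound 4, `O=C([C@@H]1C[C@@H]1F)N1CC2CC(C1)N2`, keeps every atom and bond of compound 3; the difference is the two compounds have the same atoms and bonds; at least one stereo element is drawn with a configuration in one of them and without one in the other: 2 of 4 stereo elements differ; a stereocentre at a saturated ring carbon is drawn R in compound 3 and S in compound 4; a stereocentre at a saturated ring carbon is drawn R in compound 3 and S in compound 4. Among the compounds with values here, none of the measured steps touches a stereo element: each of them swaps the group on the carbonyl carbon, so none bears directly on this change. The measured steps only show that the group on the carbonyl carbon matters, and that the 2-fluorocyclopropyl arrangement of compound 3 gives the lowest number seen. From the compounds shown here alone, whether its mirror arrangement in compound 4 is read in the same way is unknown, so a step in either direction is possible and the range must be wide. Compound 4 is estimated at 100 nM, between 15 nM and 800 nM. The expected step is a 3.7-fold higher number from compound 3 to compound 4 (0.57 log units; beyond the scatter), a weakening that remains uncertain.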

Compound 4, inhibition constant: 55 nM
For compound 4 the middle estimate is 1.8-fold (0.26 log units) above the measured one; low and high end bracket the measured number.
By their numbers in this assay, from the lowest: compound 3; then compound 4; then compounds 2 and 1 (each within the scatter of the next).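

In this assay, reversing the drawn configuration at the two saturated ring carbons of the 2-fluorocyclopropyl group gives a modest change, a 2.0-fold higher number from compound 3 to compound 4 (0.31 log units; beyond the scatter), so configuration at this position has a measurable but small bearing on the number. The choice of group on the carbonyl carbon remains the larger change, with a 6.4-fold lower number from compound 2 to compound 4 (0.80 log units; beyond the scatter) and an 11-fold lower number from compound 1 to compound 4 (1.04 log units; beyond the scatter). The lower numbers are therefore not confined to the arrangement in compound 3, as both drawn forms of the 2-fluorocyclopropyl group lie beyond the scatter from compound 1 and compound 2.

Whether the fluorine or the cyclopropyl ring accounts for these lower numbers stays open, and a plain cyclopropyl or a 2-methylcyclopropyl group on the carbonyl carbon would separate the two. The reading of the configuration step also carries a caveat: the fact that one of compounds 3 and 4 is drawn with a defined configuration and the other without, at the place where they differ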